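A few compounds are considered here, and "the series" means these few. Any claim that something is new, unique, unknown or untested is made for them only; others in the source may bear on it.

Two compounds of the series have numbers in an assay on HEK293 cells for inhibition of Voltage-dependent N-type calcium channel subunit alpha-1B (Homo sapiens), read by patch clamp, using a membrane potential dye; on this read-out higher numbers stand for weaker inhibition and lower numbers for stronger inhibition. Compound 1 `COc1ccccc1-n1nc(C2CC(C)(C)OC(C)(C)C2)cc1-c1ccc(C#N)cc1` gives 85 nM, and compound 2 `CCOc1ccc(-c2cc(C3CC(C)(C)OC(C)(C)C3)nn2-c2ccccc2OC)cn1` gives 44 nM. Going by the values given here, the one step between them, a 1.9-fold lower number from compound 1 to compound 2 (0.29 log units; within the scatter), exchanged one aryl group for another on the same carbon of the shared core, so compound 2 stands beside compound 1 with no separation beyond the scatter. Compound 3 `COc1ccccc1-n1nc(C2CC(C)(C)OC(C)(C)C2)cc1-c1csc(Cl)c1` is not yet measured in this assay; it differs from compound 2 by 5-chlorothiophen-3-yl in place of 6-ethoxypyridin-3-yl on an aromatic carbon. Among the compounds with values here, the only measured step that bears on this position is the aryl exchange from compound 1 to compound 2, which stayed within the scatter, and nothing speaks for a larger effect of a second aryl exchange at the same carbon. The expected step in this assay is therefore a 1.4-fold higher number from compound 2 to compound 3 (0.13 log units; within the scatter), none beyond the scatter. Compound 3 is estimated at 60 nM, with a range from 20 nM to 180 nM.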

Compound 3, half-maximal inhibitory concentration: 28 nM
Compound 3: middle estimate off by 2.1-fold (0.33 log units), on the high side; the range from low to high includes it.
By their numbers in this assay, from the lowest: compounds 3, 2 and 1 (each within the scatter of the next, the first and the last beyond it).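

In this assay this carbon of the shared core accepts a five-membered aromatic ring as well as a six-membered one: 5-chlorothiophen-3-yl in place of 6-ethoxypyridin-3-yl gives a 1.6-fold lower number from compound 2 to compound 3 (0.20 log units; within the scatter) and so leaves the number within the scatter despite the smaller group. Going by these compounds alone, in place of 4-cyanophenyl, the same group gives a 3.0-fold lower number from compound 1 to compound 3 (0.48 log units; beyond the scatter) and is the first exchange at this carbon to pass the scatter, though only modestly. No evidence at hand bears on the origin of this step.

On these data alone, it remains open whether a thiophen-3-yl without the chlorine, or with a methyl group there, would keep the number of compound 3. As far as these compounds go, the effect of a plain phenyl in place of 2-methoxyphenyl, or of cyclohexyl in place of 2,2,6,6-tetramethyloxan-4-yl, also stays open.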